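A Methyl on the Ring Nitrogen of Compound 1

The source may hold more compounds than are shown below. What is called first, only, known or untested is meant among the compounds shown, and "the series" means these compounds.

Measured so far:
compound 1, `Cc1ccc(S(=O)(=O)Nc2cc[nH]c(=O)n2)cc1`: > 100000 nM
compound 2, `O=c1[nH]c(=O)n(COC(CO)CO)cc1O`: > 100000 nM
compound 3, `CC(C)(C)OC(=O)NCCNCC(=O)Nc1c[nH]c(=O)[nH]c1=O`: > 100000 nM

All three were tested in a functional assay on NCI-H460 cells (Homo sapiens) for inhibition, read by MTT assay, with a stated time of 72 h; a higher number here means a weaker inhibitor, a lower number a stronger inhibitor. For compound 1 the reading of > 100000 nM is a limit of the assay, not a measured number. Compound 2 likewise reaches only the limit with > 100000 nM. Compound 3 also gives only the limit, > 100000 nM. So compound 1 stands where everything measured here stands, because the limit of > 100000 nM in this assay, at which 3 of the 3 values shown sit: no compound gave a number inside the range of the assay, and no step between two measured compounds can be drawn from these values.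

The next compound, compound 4, `Cc1ccc(S(=O)(=O)Nc2ccn(C)c(=O)n2)cc1`, differs from compound 1 in one place: methyl in place of hydrogen on an aromatic nitrogen. Compounds 2 and 3 share no such change with compound 1, so they give no guide to its effect.

Given only a limit for compound 1, the step from compound 1 to compound 4 is expected to be a number no higher from compound 1 to compound 4 (the limit leaves the size open), meaning no change beyond the scatter that can be seen. Compound 4 is therefore expected to give about 100000 nM in this assay, within a range of 30000 nM to 300000 nM, most likely again reported only as a limit.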

Compound 4, half-maximal inhibitory concentration: > 100000 nM
Compound 4 gave a limit, no number; the forecaster's own chance of this, stated with the estimate: 85%; the middle value lies on the limit itself.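

No step can be read between compound 1 and compound 4, because both results are limits and not numbers: the limit of > 100000 nM in this assay, at which 4 of the 4 values shown sit.

The compounds shown leave open whether methyl in place of hydrogen on an aromatic nitrogen changes inhibition at all, and which change to the core of compound 1 would give a measurable value.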